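The compounds below may be only part of what the source reports. "The series", "measured", "known", "first", "only" and "open" are said of these compounds alone.

Measured so far:
- compound 1, `CCCCOc1nc(C(F)(F)F)ccc1CNC(=O)Nc1cccc2[nH]c(=O)ccc12`, gives 4 nM in an assay on HEK cells for antagonist activity at transient receptor potential cation channel subfamily V member 1 (Homo sapiens), read by FLIPR; on this read-out lower numbers stand for stronger inhibition and higher numbers for weaker inhibition
- compound 2, `O=C(NCc1ccc(C(F)(F)F)nc1OCc1ccccc1)Nc1cccc2[nH]c(=O)ccc12`, gives 1.2 nM in this assay

Among the compounds with values here, compound 2 holds the lowest of the two numbers; its only neighbour is compound 1, and the single measured step, a 3.3-fold lower number from compound 1 to compound 2 (0.52 log units; beyond the scatter), came from putting phenyl in place of propyl on a saturated chain carbon bound to an oxygen on an aromatic ring. Compound 3, `O=C(NCc1ccc(C(F)(F)F)nc1SC1CCCCC1)Nc1cccc2[nH]c(=O)ccc12`, differs from compound 2 by cyclohexylsulfanyl in place of benzyloxy on an aromatic carbon. Within the data shown here, the measured step bears on this change only loosely: it shows that an aromatic ring at this end of the molecule gave a modestly lower number than a plain chain, and compound 3 gives up that aromatic ring while also exchanging the oxygen for sulfur, an exchange for which no measured pair exists. A number somewhat higher than that of compound 2 is therefore expected, yet still close to the range already seen. Compound 3 is estimated at 4 nM, with a plausible range from 1.2 nM to 15 nM. This corresponds to an expected 3.3-fold higher number from compound 2 to compound 3 (0.52 log units; beyond the scatter).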

Compound 3, half-maximal inhibitory concentration: 2.15 nM
Estimate against measurement, compound 3: 1.9-fold (0.27 log units) above; the measured number falls inside the stated range.
By their numbers in this assay, from the lowest: compounds 2, 3 and 1 (each within the scatter of the next, the first and the last beyond it).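

In this assay, cyclohexylsulfanyl in place of benzyloxy gives a 1.8-fold higher number from compound 2 to compound 3 (0.25 log units; within the scatter) and so stays within the scatter, which shows that at this position, next to the ring nitrogen, a low number does not depend on an aromatic ring of carbon in the group: compound 3 carries a non-aromatic ring and a sulfur in place of the oxygen. Set against the open chain of compound 1, the same group gives a 1.9-fold lower number from compound 1 to compound 3 (0.27 log units; within the scatter) and is again within the scatter, so compound 3 cannot be told apart from either neighbour, even though compound 1 and compound 2 lie beyond the scatter of each other. Nothing measured here offers a reason why these different groups give such similar numbers.

The compounds shown leave open how much of the result belongs to the sulfur and how much to the ring, a question that cyclohexyloxy or benzylsulfanyl would each address by changing only one of the two. They also leave open how a group of a different kind, such as an amine or a carboxylic acid, would read at this position.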